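A few compounds are considered here, and "the series" means these few. Any claim that something is new, unique, unknown or untested is made for them only; others in the source may bear on it.

Two members of the series have so far been run in a functional assay on HCT-116 cells (Homo sapiens) for antiproliferative activity, read by MTT assay, with a stated time of 48 h; a higher number here means a weaker inhibitor, a lower number a stronger inhibitor. Compound 1 `N#CC1=C(N)Oc2c(c3nc4ccccc4nc3c3ccccc23)C12C(=O)N(Cc1cnnn1-c1ccc(F)c(Cl)c1)c1ccccc12` returns only a limit of the assay in this assay, > 50000 nM, with no number behind it. Compound 2 `Cc1cccc(-n2nncc2CN2C(=O)C3(C(C#N)=C(N)Oc4c(N)cc5nc6ccccc6nc5c43)c3ccccc32)c1` likewise returns only a limit in this assay, > 50000 nM. Where compound 2 stands is therefore fixed only in outline: it sits at the limit of > 50000 nM in this assay, at which 2 of the 2 values shown sit, and with both entries at the limit no step between measured compounds can be drawn from them.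

Compound 3 `CC(=O)Nc1ccc(-n2nncc2CN2C(=O)C3(C(C#N)=C(N)Oc4c(N)cc5nc6ccccc6nc5c43)c3ccccc32)cc1` is the next member to be measured in this assay. It differs from compound 2 in a single place: 4-acetamidophenyl in place of 3-methylphenyl on an aromatic nitrogen.

Among the measured compounds shown here, with no measured step to lean on and both known values resting at the limit, no direction can be assigned to this change. The expected step from compound 2 to compound 3 is a step that the limit leaves unreadable from compound 2 to compound 3, nothing beyond the scatter. The estimate for compound 3 in this assay is 70000 nM, within 20000 nM to 250000 nM, and the most likely outcome is again a limit rather than a number.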

Compound 3, half-maximal inhibitory concentration: > 50000 nM
Compound 3 was reported as a limit; the forecaster's own chance of this, stated with the estimate: 80%; the middle value lies beyond the limit too.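

In this assay compound 3 gives > 50000 nM, a limit and not a number. No step can be read from compound 2 to compound 3, so 4-acetamidophenyl in place of 3-methylphenyl has neither size nor direction here. The compounds shown leave open how any single change moves activity, because all of them rest at one value: the limit of > 50000 nM in this assay, at which 3 of the 3 values shown sit.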